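The compounds below may be only part of what the source reports. "The series", "measured", "known", "first", "only" and "open" are said of these compounds alone.

Three compounds built on one shared core, differing only in the aryl group on a carbon with a double bond to nitrogen, have been tested in a functional assay on PC-3 cells (Homo sapiens) for antiproliferative activity, read by MTT assay; a lower number here means a stronger inhibitor, a higher number a weaker inhibitor. Compound 1 `Cn1c(=O)c(=O)n(C2CCCC2)c2nc(N/N=C/c3cccs3)ncc21` gives 75600 nM. Compound 2 `Cc1ccc(/C=N/Nc2ncc3c(n2)n(C2CCCC2)c(=O)c(=O)n3C)cc1C` gives 39000 nM. Compound 3 `Cn1c(=O)c(=O)n(C2CCCC2)c2nc(N/N=C/c3ccccc3F)ncc21` gives 27600 nM, the lowest of the three numbers: its gap to compound 2 is within the scatter, while its gap to compound 1 is beyond it.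

Compound 4 `Cn1c(=O)c(=O)n(C2CCCC2)c2nc(N/N=C/c3ccc(O)c(Br)c3)ncc21` has not yet been measured in this assay. It differs from compound 3 in one place: 3-bromo-4-hydroxyphenyl in place of 2-fluorophenyl on a carbon with a double bond to nitrogen.

The steps already seen at this same position bear on this change. From compound 1 to compound 2 the number moved by a 1.9-fold lower number from compound 1 to compound 2 (0.29 log units; within the scatter); from compound 1 to compound 3 by a 2.7-fold lower number from compound 1 to compound 3 (0.44 log units; beyond the scatter); from compound 2 to compound 3 by a 1.4-fold lower number from compound 2 to compound 3 (0.15 log units; within the scatter). All three exchanges of the aryl group produced small steps, only one of them beyond the scatter, so another exchange at this position is expected to give at most a modest step in this assay, in either direction or none beyond the scatter. The expected step is a 1.1-fold lower number from compound 3 to compound 4 (0.04 log units; within the scatter). Compound 4 is accordingly estimated at 25000 nM, with a range from 8000 nM to 80000 nM.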

Compound 4, half-maximal inhibitory concentration: 11600 nM
For compound 4 the middle estimate is 2.2-fold (0.33 log units) above the measured one, and the stated range covers the measured number.
By their numbers in this assay, from the lowest: compound 4; then compounds 3, 2 and 1 (each within the scatter of the next, the first and the last beyond it).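

In this assay, among these compounds, the step sizes at this position grow with the 3-bromo-4-hydroxyphenyl group, which gives the strongest inhibitor of the four, with a 2.4-fold lower number from compound 3 to compound 4 (0.38 log units; beyond the scatter) and a 3.4-fold lower number from compound 2 to compound 4 (0.53 log units; beyond the scatter) and a 6.5-fold lower number from compound 1 to compound 4 (0.81 log units; beyond the scatter) all beyond the scatter, whereas only one of the earlier exchanges, a 2.7-fold lower number from compound 1 to compound 3 (0.44 log units; beyond the scatter), had cleared it. The position therefore allows a wider spread than the first three compounds showed, although every step seen so far remains modest, and the entering group carries a hydrogen-bond donor and a hydrogen-bond acceptor where the 2-fluorophenyl it replaces carries neither. Nothing available explains why this exchange goes with a lower number.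

The compounds shown leave open which of the bromine and the hydroxyl goes with that lower number, as the two occur together and only in compound 4, so a phenyl ring bearing just one of them would be needed to separate them. Also open, from the compounds shown here alone, is how a phenyl ring bearing an amine or a carboxylic acid would behave at this position.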